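The compounds below may be only part of what the source reports. "The series", "measured", "known", "first", "only" and "open" are said of these compounds alone.

Measured in a functional assay on MDA-MB-435 cells (Homo sapiens) for antiproliferative activity; a higher number here means a weaker inhibitor of growth, a lower number a stronger inhibitor of growth:
- Compound 1 `Cc1ccnc2nc(-c3cccc(Cl)c3)cc(O)c12`: < 10 nM
- Compound 2 `Cc1ccc2c(O)cc(-c3cccc(Cl)c3)nc2n1`: < 10 nM
- Compound 3 `Cc1ccnc2nc(-c3ccc4ccccc4c3)cc(O)c12`: 204 nM

Only one of these three entries is an actual number. Compound 1 gives < 10 nM, which is a limit of the assay and not a number. Compound 2 gives < 10 nM, which is also a limit. Among the measured compounds shown here, compound 3, at 204 nM, is therefore the only compound with a measured number in this assay, while the limit of < 10 nM in this assay, at which 2 of the 3 values shown sit, accounts for the other two.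

The next compound is compound 4 `Cc1cc(C)c2c(O)cc(-c3ccc4ccccc4c3)nc2n1`, and it is built from compound 3 by one small change: methyl in place of hydrogen on an aromatic carbon. In words, a methyl takes the place of a hydrogen on an aromatic carbon, next to the ring nitrogen. The measured compounds give no number for what such a methyl does, so any forecast has to start from compound 3 and its 204 nM. For the measured compounds named here, with so small a change and no measured step to suggest a direction, only a modest shift seems likely, probably no larger than the usual scatter. The estimated 1.1-fold lower number from compound 3 to compound 4 (0.05 log units; within the scatter) is expected to be small. For compound 4 the expected value is 180 nM, with an estimated range of 50 nM to 700 nM.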

Compound 4, concentration for 50% growth inhibition: 2950 nM
The estimate for compound 4 lay 16-fold (1.21 log units) below the measured number; the whole stated range lies below it.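

In this assay the added methyl produces a 14-fold higher number from compound 3 to compound 4 (1.16 log units; beyond the scatter) and so marks a loss of growth inhibition. Among the compounds shown here, this is the first measured step at this position, and it shows that the position is sensitive: one methyl, a single heavy atom on an aromatic carbon next to the ring nitrogen, moves the result well beyond the scatter. At least with the rest of compound 3 held fixed, even the smallest carbon group is not a neutral change here.

As far as these compounds go, whether other groups at this position, such as an ethyl, a methoxy or an amine, would cost as much, cost more or restore growth inhibition remains open, and one step cannot say whether the loss tracks the size of the group or something else about it. From the compounds shown here alone, it is also open whether the same methyl would matter as much with the chlorine-bearing aryl group of compound 1 and compound 2, whose entries are limits and give no number to start from: the limit of < 10 nM in this assay, at which 2 of the 4 values shown sit.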